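A few compounds are considered here, and "the series" means these few. Any claim that something is new, unique, unknown or untested is made for them only; others in the source may bear on it.

Of the compounds shown here, three built on a shared core have been tested so far in a functional assay on MGC-803 cells (Homo sapiens) for antiproliferative activity, read by MTT assay, with a stated time of 72 h; on this read-out lower numbers stand for stronger inhibition and higher numbers for weaker inhibition. Compound 1 (`CCCSc1nc(N/N=C(\C)c2ccccc2O)c2nnn(Cc3ccc(Cl)cc3)c2n1`) gives 7100 nM, and compound 3 (`C#CCSc1nc(N/N=C/c2ccc(N(C)C)cc2)c2nnn(Cc3ccccc3)c2n1`) gives 7620 nM. Compound 2 (`CCCSc1nc(N/N=C/c2cccnc2)c2nnn(Cc3ccccc3)c2n1`) gives 38100 nM, the highest number of the three and so the weakest inhibition, with a gap to each of the others that lies beyond the scatter.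

Compound 4 (`CCCSc1nc(N/N=C/c2ccccc2Cl)c2nnn(Cc3ccccc3)c2n1`) has not yet been measured. Compared with compound 2, it changes one group: 2-chlorophenyl in place of pyridin-3-yl on a carbon with a double bond to nitrogen. The pyridin-3-yl is replaced by 2-chlorophenyl, on a carbon with a double bond to nitrogen.

Going by the values given here, no two measured compounds differ in only one place, so no direct step can guide this change. There is only a weak hint: compound 1 at 7100 nM and compound 3 at 7620 nM both carry an aromatic ring of carbon only on that carbon, as compound 4 does, although both also differ from compound 2 elsewhere. In this assay the number is expected to fall, with an estimated step of a 3.2-fold lower number from compound 2 to compound 4 (0.50 log units; beyond the scatter), which would lie beyond the scatter. The estimate for compound 4 is 12000 nM, with an expected range from 4000 nM to 32000 nM.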

Compound 4, half-maximal inhibitory concentration: 10900 nM
Estimate against measurement, compound 4: 1.1-fold (0.04 log units) above; the range from low to high includes it.
By their numbers in this assay, from the lowest: compounds 1, 3 and 4 (each within the scatter of the next); then compound 2.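

In this assay, going by these compounds alone, putting 2-chlorophenyl in place of pyridin-3-yl on a carbon with a double bond to nitrogen gives a 3.5-fold lower number from compound 2 to compound 4 (0.54 log units; beyond the scatter), and this is the first direct reading at this position, with the rest of the molecule held the same. It shows that the group on this carbon can move the antiproliferative read-out on its own, without any change elsewhere on the shared core. The swap alters two things at once, since the ring nitrogen with its hydrogen-bond acceptor leaves and a chlorine enters, and no measurement shown here explains why the number falls.

A plain phenyl ring on this carbon would help separate the loss of the ring nitrogen from the gain of the chlorine, while 2-fluorophenyl or 2-methylphenyl would test whether chlorine itself matters or another small group would serve as well. Going by these compounds, it also remains open whether the same swap gives a step of similar size when the chain on sulfur or the benzyl group on the shared core is different.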